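A few compounds are considered here, and "the series" means these few. Any claim that something is new, unique, unknown or untested is made for them only; others in the source may bear on it.

Compound 1, `NS(=O)(=O)c1cccc(-c2ccc3nccc(-c4ccncc4)c3n2)c1`, was measured in a physicochemical assay for solubility, read by HPLC, using the shake flask method, measured as kinetic solubility, with a stated time of 20 h, at pH 6.5, tested at 200 uM (on this read-out lower numbers stand for lower solubility and higher numbers for higher solubility), and the value of compound 1 there, < 5000 nM, is a limit of the assay rather than a number. Compound 2, `NS(=O)(=O)c1cccc(-c2ccc3nccc(-c4ccncc4F)c3n2)c1`, also sits at a limit in this assay, giving < 5000 nM. Compound 3, `CN1CCN(c2ccnc3ccc(-c4cccc(S(N)(=O)=O)c4)nc23)CC1`, gives 200000 nM in this assay. Two of the three values share (the limit of < 5000 nM in this assay, at which 2 of the 3 values shown sit). The steps of an at least 40-fold higher number from compound 1 to compound 3 (1.60 log units; beyond the scatter) and an at least 40-fold higher number from compound 2 to compound 3 (1.60 log units; beyond the scatter) alter a different part of the shared core, while the step that the two limits leave unreadable from compound 1 to compound 2 cannot be sized. Within the data shown here, compound 4, `CS(=O)(=O)Nc1cccc(-c2ccc3nccc(-c4ccncc4)c3n2)c1`, differs from compound 1 by methanesulfonamido in place of sulfamoyl on an aromatic carbon, a change that no measured step covers. Compound 4 is expected to move little, a step that the limit leaves unreadable from compound 1 to compound 4, and is estimated at 4000 nM, between 1000 nM and 20000 nM.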

Compound 4, solubility: 20000 nM
For compound 4 the middle estimate is 5.0-fold (0.70 log units) below the measured one; the measured number falls inside the stated range.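

In this assay, the step at this place on the carbon-only aromatic ring, an at least 4.0-fold higher number from compound 1 to compound 4 (0.60 log units; beyond the scatter), shows that the read-out responds here too, and not only where compound 3 differs from compound 1. Compound 4 also keeps the pyridin-4-yl group and still gives a number, unlike compound 1 and compound 2. The step is only a lower bound, because the value of compound 1 is a limit: the limit of < 5000 nM in this assay, at which 2 of the 4 values shown sit.

The compounds shown leave open how an amine or a carboxylic acid in place of methanesulfonamido would read in this assay. They also leave open whether methanesulfonamido would act alike alongside the 4-methylpiperazin-1-yl group of compound 3.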